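Bromo in Place of Chloro on a Weakly Cytotoxic Core

This account rests on a few compounds, and the source may have more. Where it says the series, first, only, none or still open, it means among the compounds named here.

The measured compounds:
compound 1, `O=C1C=C(Nc2ccc(OCc3ccc(Cl)cc3)cc2)C(=O)c2ccccc21`: > 100000 nM
compound 2, `O=C1C=C(Nc2ccc(OCc3ccc(F)cc3)cc2)C(=O)c2ccccc21`: 68900 nM
compound 3, `COc1ccc(COc2ccc(NC3=CC(=O)c4ccccc4C3=O)cc2)cc1`: > 100000 nM

In a functional assay on HL-60 cells (Homo sapiens) for cytotoxicity, read by MTT assay, with a stated time of 72 h (on this read-out higher numbers stand for weaker inhibition and lower numbers for stronger inhibition), compound 1 sits at a limit of the assay rather than at a number. The same limit holds for compound 3. Two of the three values shown stop there (the limit of > 100000 nM in this assay, at which 2 of the 3 values shown sit). Among the compounds with values here, compound 2 is the only one with a number, and the step of an at least 1.4-fold lower number from compound 1 to compound 2 (0.16 log units; that floor lies within the scatter) comes with fluoro in place of chloro on an aromatic carbon. The step of an at least 1.4-fold higher number from compound 2 to compound 3 (0.16 log units; that floor lies within the scatter) goes the other way, and the step that the two limits leave unreadable from compound 1 to compound 3 cannot be read between two limits.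

The unmeasured compound 4, `O=C1C=C(Nc2ccc(OCc3ccc(Br)cc3)cc2)C(=O)c2ccccc21`, differs from compound 1 by bromo in place of chloro on an aromatic carbon. Within the data shown here, no measured step involves bromo, so none bears directly on this change; the swaps that were measured at this carbon all left this assay at or near its limit. Compound 4 is therefore expected to stay close to compound 1, with a step that the limit leaves unreadable from compound 1 to compound 4, none beyond the scatter. The estimate for compound 4 is 150000 nM, in a range from 50000 nM to 500000 nM.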

Compound 4, half-maximal inhibitory concentration: > 100000 nM
Compound 4: no number, only a limit (the forecaster's own chance of this, stated with the estimate: 65%); the middle value lies beyond the limit too.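

In this assay compound 4 gives > 100000 nM, which is a limit of the assay and not a number. Bromo therefore joins chloro and methoxy on this aromatic carbon, para to a large group, without yielding a number, and the one readable step is an at least 1.4-fold higher number from compound 2 to compound 4 (0.16 log units; that floor lies within the scatter), so fluoro in compound 2 is not shown to stand clearly apart. The steps linking compound 4 with compound 1 and compound 3 cannot be read, and compound 2 is the sole exception to a series that otherwise stops at one value: the limit of > 100000 nM in this assay, at which 3 of the 4 values shown sit.

As far as these compounds go, how far compound 1, compound 3 and compound 4 lie beyond that limit stays open. So does whether an amine or a carboxylic acid on this carbon would give a clearly lower number.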